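This account rests on a few compounds, and the source may have more. Where it says the series, first, only, none or still open, it means among the compounds named here.

Measured compounds:
- compound 1, `O/N=C(/Nc1cccc(Cl)c1)c1ccc2occc2c1`: 1500 nM
- compound 2, `O/N=C(/Nc1cccc(F)c1)c1ccc2oc(-c3ccccc3)cc2c1`: 10600 nM

In an assay on tissue (HeLa cells) for inhibition of Indoleamine 2,3-dioxygenase 1 (Homo sapiens), read by spectrophotometry (a lower number here means a stronger inhibitor, a higher number a weaker inhibitor), compound 2 gives the higher of the two numbers, and its gap to compound 1 lies beyond the scatter. Compound 3, `O/N=C(/Nc1cccc(Cl)c1)c1ccc2oc(-c3ccccc3)cc2c1`, is not yet measured; it differs from compound 2 by chloro in place of fluoro on an aromatic carbon. Within the data shown here, no pair of measured compounds isolates this halogen swap, so its size is open. A shift toward a lower number is expected, since compound 1, the other chloro compound, gives the lower value at 1500 nM. For compound 3 the estimate is 5000 nM, within 2000 nM to 15000 nM, a step of a 2.1-fold lower number from compound 2 to compound 3 (0.33 log units; beyond the scatter) expected in this assay.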

Compound 3, half-maximal inhibitory concentration: 10800 nM
The estimate for compound 3 lay 2.2-fold (0.33 log units) below the measured number; measured number inside the range.
By their numbers in this assay, from the lowest: compound 1; then compounds 2 and 3 (each within the scatter of the next).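

In this assay, chloro in place of fluoro on the aromatic carbon gives a 1.0-fold higher number from compound 2 to compound 3 (0.01 log units; within the scatter), so with the phenyl present, 3-fluorophenyl and 3-chlorophenyl read alike at this position. Phenyl in place of hydrogen on an aromatic carbon gives a 7.2-fold higher number from compound 1 to compound 3 (0.86 log units; beyond the scatter), which places the difference at the phenyl rather than at the halogen. No supporting data bear on why either step has its size. Still open, going by these compounds, is whether the halogen swap reads the same on the core of compound 1, without the phenyl. Also open, on these data alone, is where an amine or a methyl in place of that phenyl would fall in this assay.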